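Removing the nitrogen methyl from compound 1

The compounds below may be only part of what the source reports. "The series", "measured", "known", "first", "only" and "open" are said of these compounds alone.

In a functional assay on Caco-2 cells (Homo sapiens) for cytotoxicity, read by MTT assay, with stated times of 6 h and 48 h (a lower number here means a stronger inhibitor, a higher number a weaker inhibitor), compound 1 `Cn1c(/C=C/C(=O)c2ccccc2)cc(Br)c1Br` gives >= 100000 nM and this is a limit, not a number. Compound 2 `Cn1c(/C=C/C(=O)c2cccc(O)c2)cc(Br)c1Br` gives >= 100000 nM and this too is a limit. The evidence so far amounts to the limit of >= 100000 nM in this assay, at which 2 of the 2 values shown sit, and no measured number exists in the series.

Compound 3 `O=C(/C=C/c1cc(Br)c(Br)[nH]1)c1ccccc1` has hydrogen in place of methyl on an aromatic nitrogen, counted as hydrogen in place of methyl on an aromatic nitrogen in full. Among the measured compounds shown here, no measured step touches that nitrogen. For the measured compounds named here, the only measured step that the two limits leave unreadable from compound 1 to compound 2 is hydroxy in place of hydrogen on an aromatic carbon and offers no size to carry over, so no step beyond the scatter is expected, in either direction. The estimated change is a number no higher from compound 1 to compound 3 (the limit leaves the size open) and this assay may well report only a limit again. For compound 3 the expected value is 100000 nM with an estimated range of 30000 nM to 300000 nM around it.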

Compound 3, half-maximal inhibitory concentration: >= 100000 nM
Compound 3: a limit, no number; the forecaster's own chance of this, stated with the estimate: 70%; the middle value sits exactly at the limit.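

Among the compounds shown here, compound 1, compound 2 and compound 3 all give limits, not numbers, in this assay, so no step among them can be read. The compounds shown leave open whether either change, at the aromatic nitrogen or on the aromatic carbon, alters the read-out at all.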